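The source may report more compounds than this note shows. Statements on the series, on what has been measured and on what is new or still open speak of the compounds shown alone.

Working notes on the series.

Of the compounds shown here, three have been measured in an assay on isolated protein for inhibition of Indoleamine 2,3-dioxygenase 1 (Homo sapiens), with a stated time of 60 min, tested at 10 uM; a higher number here means more inhibition at the concentration tested (going by the name of the read-out), a lower number less inhibition. Compound 1 `c1ccc(CCc2ccccc2CSc2nccs2)cc1` gives 31%. Compound 2 `O=S(=O)(Cc1ccccc1)c1ccccc1CSc1nc2cc(Cl)ccc2[nH]1` gives 24%. Compound 3 `Clc1ccc2[nH]c(SCc3ccccc3CCc3ccccc3)nc2c1` gives 47%, the highest of the three numbers; its nearest neighbour is compound 1, sitting lower by a margin beyond the scatter, and compound 2 sits further below, also beyond the scatter. No pair among these three differs in a single place, so no measured single step is available.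

Compound 4 `[O-][S+](Cc1ccccc1)c1ccccc1CSc1nc2cc(Cl)ccc2[nH]1` has not yet been measured. It differs from compound 3 as follows: a group of 9 heavy atoms (7 carbon, 1 oxygen, 1 sulfur; one six-membered aromatic ring of carbon only) in place of a group of 8 heavy atoms (8 carbon; one six-membered aromatic ring of carbon only), on an aromatic carbon.

The change moves the series from the phenethyl-bearing compound 3 toward compounds of the kind represented by compound 2, and compound 2 gives only 24% in this assay. On that basis the step from compound 3 to compound 4 is expected to be downward, a number 19 percentage points lower from compound 3 to compound 4 (beyond the scatter), and beyond the scatter. Compound 4 is therefore estimated at 28%, with a range from 12% to 45%.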

Compound 4, a percentage reported as inhibition, at one concentration (the size of the read-out at that concentration, not a potency): 11%
Estimate against measurement, compound 4: 17 percentage points above, outside the stated range (below it).
By their numbers in this assay, from the lowest: compound 4; then compounds 2 and 1 (each within the scatter of the next); then compound 3.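

Going by these compounds alone, putting the group of 9 heavy atoms in place of phenethyl, on an aromatic carbon ortho to a large group, gives a number 36 percentage points lower from compound 3 to compound 4 (beyond the scatter) in this assay, the first measured single step. Both groups carry a six-membered aromatic ring of carbon only, so that ring alone does not set the number at this position, and the read-out here depends strongly on what else the group holds. No measurement at hand bears on why the number falls.

One step cannot separate the part played by the sulfur and oxygen of the entering group from that of the group as a whole; a benzylthio group or a longer carbon chain on the same carbon would bear on this. As far as these compounds go, whether the step carries over to the core of compound 1 also stays open.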